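The source may hold more compounds than are shown below. What is called first, only, known or untested is meant among the compounds shown, and "the series" means these compounds.

Measured compounds: compound 1 `CCOc1ccc(-c2cccc(S(=O)(=O)N(C)C)c2)cc1` gives 110000 nM in an assay on COS-7 cells for inhibition of patatin-like phospholipase domain-containing protein 2 (Mus musculus); a higher number here means a weaker inhibitor, a lower number a stronger inhibitor; compound 2 `CCOc1ccc(-c2cccc(C)c2)cc1` gives 70000 nM in this assay.

Among the measured compounds shown here, compound 2 holds the lowest of the two numbers so far, but its only neighbour is compound 1, and the step from compound 1 to compound 2 is a 1.6-fold lower number from compound 1 to compound 2 (0.20 log units; within the scatter), so the two cannot be ordered.

Compound 3 `CCOc1ccc(-c2cccc(C(=O)O)c2)cc1` is not yet measured. Against compound 2 the change is carboxy in place of methyl on an aromatic carbon. For the measured compounds named here, the one measured step that touches this position, a 1.6-fold lower number from compound 1 to compound 2 (0.20 log units; within the scatter), swapped one group for another on the same aromatic carbon without moving the number beyond the scatter; it is the only guide, and it involves neither a carboxy nor a hydrogen-bond donor, so it bears on the new step only loosely. On that basis no change beyond the scatter is expected for compound 3 in this assay, with a wide range to allow for the untested group; the expected step is a 1.4-fold higher number from compound 2 to compound 3 (0.15 log units; within the scatter).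

For compound 3 the estimate in this assay is 100000 nM, from 30000 nM to 300000 nM.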

Compound 3, half-maximal inhibitory concentration: > 200000 nM
Compound 3: only a limit was reported (the forecaster's own chance of this, stated with the estimate: 30%); middle value at least 2.0-fold (0.30 log units) from the limit.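

In this assay compound 3 gives > 200000 nM, which is a limit of the assay and not a number. Even so, the position proves not to be indifferent to every replacement: carboxy in place of methyl on this aromatic carbon gives an at least 2.8-fold higher number from compound 2 to compound 3 (0.45 log units; beyond the scatter), the first step here to clear the scatter, whereas the earlier exchange of dimethylsulfamoyl for methyl stayed inside it. Carboxy in place of dimethylsulfamoyl gives an at least 1.8-fold higher number from compound 1 to compound 3 (0.25 log units; that floor lies within the scatter), and since that floor lies within the scatter, this pair stays unordered, so the change is established only against methyl.

From the compounds shown here alone, the true size of both steps stays open, since each rests on a limit, and so does the question of whether the rise in the number belongs to carboxy alone or would also appear with a primary amide, a hydroxymethyl group or an amine on the same carbon. Also open is whether any group at this position, such as a plain hydrogen or a longer alkyl chain, would bring the number clearly lower than the values of the compounds shown.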